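Replacing a hydroxyphenyl by methoxyphenyl: cytotoxicity outlook

The compounds below may be only part of what the source reports. "The series", "measured", "known", "first", "only" and "open" are said of these compounds alone.

The three measured compounds share a core in which a saturated ring carbon carries an aryl group. Compound 1 `COc1ccc(C2CC(c3cc4ccccc4o3)=NN2C(=O)c2ccncc2)c(O)c1` was tested in an ADME assay on Vero cells (Chlorocebus sabaeus) for cytotoxicity, read by MTT assay, with a stated time of 72 h; a higher number here means a weaker inhibitor, a lower number a stronger inhibitor. In this assay compound 1 gives only a limit, > 190000 nM. Compound 2 `O=C(c1ccncc1)N1N=C(c2cc3ccccc3o2)CC1c1ccc(O)cc1` likewise reaches only a limit in this assay, > 200000 nM. Within the data shown here, the single measured step, a step that the two limits leave unreadable from compound 1 to compound 2, therefore cannot be read. Compound 3 `CCn1cc(C(=O)N2N=C(c3cc4ccccc4o3)CC2c2ccccc2O)c(=O)c2ccc(C)nc21` in this assay also stops at a limit, > 157000 nM. Compound 3 thus stands at a limit, as do the two other compounds, and none of the three yields a number.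

Compound 4 `CCn1cc(C(=O)N2N=C(c3cc4ccccc4o3)CC2c2ccc(OC)cc2)c(=O)c2ccc(C)nc21` differs from compound 3 by 4-methoxyphenyl in place of 2-hydroxyphenyl on a saturated ring carbon. Among the measured compounds shown here, no measured step covers this change directly; the only step available, a step that the two limits leave unreadable from compound 1 to compound 2, is itself unreadable since both of its ends are limits. What the three values do show is that each variation of the aryl group on the saturated ring carbon has so far remained at a limit of this assay. The step that the limit leaves unreadable from compound 3 to compound 4 is therefore expected to be none beyond the scatter. Compound 4 is expected to give 200000 nM in this assay, within a range from 100000 nM to 400000 nM, and most probably only a limit once more.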

Compound 4, half-maximal inhibitory concentration: > 156000 nM
Compound 4: a limit, no number; the forecaster's own chance of this, stated with the estimate: 85%; the middle value lies beyond the limit too.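

In this assay compound 4 gives > 156000 nM, which is a limit and not a number. Compound 3 also stands at a limit, and the step between compound 3 and compound 4 cannot be read. The compounds shown leave open whether any change of the aryl group on the saturated ring carbon alters the result in this assay.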